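Ring swap on the aromatic nitrogen: estimate for compound 3

The source may hold more compounds than are shown below. What is called first, only, known or untested is meant among the compounds shown, and "the series" means these compounds.

Compound 1 `Cc1c(Nc2nc(N)c3c(C#N)c(N4CCC[C@H]4C)n(C)c3n2)cnn1CC1(O)COC1` gives 120 nM in an assay on HEK293 cells for inhibition of Leucine-rich repeat serine/threonine-protein kinase 2 variant G2019S (Homo sapiens), with a stated time of 48 h; a lower number here means a stronger inhibitor, a higher number a weaker inhibitor.
Compound 2 `Cc1c(Nc2nc(N)c3c(C#N)c(N4CCC[C@H]4C)n(C)c3n2)cnn1C1COC1` gives 190 nM in this assay.

Among the measured compounds shown here, compound 2 holds the higher of the two numbers so far; its only neighbour is compound 1, and the step of a 1.6-fold higher number from compound 1 to compound 2 (0.20 log units; within the scatter) lies within the scatter, so the two cannot be ordered. Compound 3 `Cc1c(Nc2nc(N)c3c(C#N)c(N4CCC[C@H]4C)n(C)c3n2)cnn1[C@@H]1CCOC1` is the untested member of the series: oxolan-3-yl in place of oxetan-3-yl on an aromatic nitrogen. For the measured compounds named here, the one measured step that bears on this position is a 1.6-fold higher number from compound 1 to compound 2 (0.20 log units; within the scatter), in which a quite different group was exchanged on the same aromatic nitrogen without moving the number beyond the scatter. Nothing measured speaks for a shift in either direction from a larger saturated ring in this place, so no step beyond the scatter is expected in this assay. Compound 3 is therefore estimated at 200 nM, with a range of 80 nM to 500 nM, which amounts to an expected step of a 1.1-fold higher number from compound 2 to compound 3 (0.02 log units; within the scatter).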

Compound 3, half-maximal inhibitory concentration: 80 nM
Beside the measured number, compound 3's estimate is 2.5-fold (0.40 log units) above it; measured number inside the range.
By their numbers in this assay, from the lowest: compounds 3, 1 and 2 (each within the scatter of the next, the first and the last beyond it).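

In this assay, among the compounds shown here, the oxolan-3-yl group in place of oxetan-3-yl on the aromatic nitrogen gives the first step at this position that lies beyond the scatter (a 2.4-fold lower number from compound 2 to compound 3 (0.38 log units; beyond the scatter)), so a change of one ring size here can move the number. The same oxolan-3-yl group in place of (3-hydroxyoxetan-3-yl)methyl stays within the scatter (a 1.5-fold lower number from compound 1 to compound 3 (0.18 log units; within the scatter)), so these two groups cannot be ordered. Nothing measured here explains the difference between the two rings.

Open, as far as these compounds go, is whether the opposite configuration at the oxolan-3-yl stereocentre gives a similar number. Also open, from the compounds shown here alone, is how this position responds to a larger ring such as oxan-4-yl, or to a ring amine such as pyrrolidin-3-yl.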